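From 4-methylphenyl to phenyl: compound 3 to compound 4

The compounds below may be only part of what the source reports. "The series", "measured", "known", "first", "only" and "open" are said of these compounds alone.

In a functional assay on thoracic aorta (Rattus norvegicus, strain Wistar), with a stated time of 15 min (on this read-out higher numbers stand for an effect only at larger amounts of compound and lower numbers for an effect already at smaller amounts), compound 1 (`COc1ccc(Br)cc1C(C)NC(=O)N(C)S(=O)(=O)c1ccccc1`) gives 16800 nM while compound 2 (`CCOc1ccc(F)cc1C(C)NC(=O)N(C)S(=O)(=O)c1ccccc1`) gives 11500 nM and compound 3 (`COc1ccc(F)cc1C(C)NC(=O)N(C)S(=O)(=O)c1ccc(C)cc1`) gives 11700 nM as its reading. Compound 3 lies within the scatter of both other compounds, so the three numbers support no ranking. Compound 4 (`COc1ccc(F)cc1C(C)NC(=O)N(C)S(=O)(=O)c1ccccc1`) is still unmeasured and differs from compound 3 (hydrogen in place of methyl on an aromatic carbon) by hydrogen in place of methyl on an aromatic carbon, the 4-methylphenyl to phenyl change. Within the data shown here, no measured pair shows this change alone, and the only guide is compound 2 at 11500 nM and compound 3 at 11700 nM in a close group. In this assay no change beyond the scatter is expected, with the estimated 1.1-fold higher number from compound 3 to compound 4 (0.03 log units; within the scatter) being small. For compound 4 the estimated value is 12500 nM with 6500 nM to 24000 nM as the expected range.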

Compound 4, half-maximal effective concentration: 10000 nM
The estimate for compound 4 lay 1.3-fold (0.10 log units) above the measured number, within the range that was stated.
By their numbers in this assay, from the lowest: compounds 4, 2, 3 and 1 (each within the scatter of the next).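

In this assay, the 4-methylphenyl to phenyl change leaves the reading within the scatter (a 1.2-fold lower number from compound 3 to compound 4 (0.07 log units; within the scatter)), so the methyl at this place on the aromatic ring is not needed to hold the number. Among these compounds, the single changes at the other two places, shortening ethoxy to methoxy (a 1.2-fold lower number from compound 2 to compound 4 (0.06 log units; within the scatter)) and fluoro in place of bromo (a 1.7-fold lower number from compound 1 to compound 4 (0.23 log units; within the scatter)), also stay within the scatter. Nothing available explains why these readings lie so close. Open, on these data alone, is whether a group of another kind at this place, such as an amine or a carboxylic acid, would shift the reading beyond the scatter.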